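Removing a Fluorine From Two Compounds Without Measured Activity

This account rests on a few compounds, and the source may have more. Where it says the series, first, only, none or still open, it means among the compounds named here.

Three compounds sharing a related core were tested in a functional assay on PC-3 cells (Homo sapiens) for antiproliferative activity, read by MTT assay, with a stated time of 48 h; on this read-out higher numbers stand for weaker inhibition and lower numbers for stronger inhibition. Compound 1 `Cc1ccc2nc(Nc3nc(Nc4ccc(S(C)(=O)=O)cc4)ncc3F)sc2c1` gives > 50000 nM, which is a limit of the assay rather than a number. Compound 2 `COc1ccc2nc(Nc3nc(Nc4ccc(S(N)(=O)=O)cc4)ncc3F)sc2c1` gives > 50000 nM in this assay, again only a limit. The difference between the cores of compound 1 and compound 2 is not broken down here. Compound 3 `Cc1ccc2nc(Nc3ccnc(Nc4ccc(S(C)(=O)=O)cc4)n3)sc2c1` gives > 50000 nM in this assay, also a limit. Compound 3 arises from compound 1 by hydrogen in place of fluoro on an aromatic carbon, and the step that the two limits leave unreadable from compound 1 to compound 3 cannot be sized because the limit of > 50000 nM in this assay, at which 3 of the 3 values shown sit, leaves both ends open. Compound 4 `COc1ccc2nc(Nc3ccnc(Nc4ccc(S(N)(=O)=O)cc4)n3)sc2c1` has not yet been measured; it arises from compound 2 by hydrogen in place of fluoro on an aromatic carbon, the same change at the same kind of place. Because the limit of > 50000 nM in this assay, at which 3 of the 3 values shown sit, holds for every value shown, nothing indicates that replacing the fluoro with hydrogen brings activity into the measurable range. Compound 4 is therefore expected to sit at the same limit, so the step that the limit leaves unreadable from compound 2 to compound 4 is estimated to be essentially none. The expected value for compound 4 is 70000 nM, with an estimated range from 30000 nM to 300000 nM.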

Compound 4, half-maximal inhibitory concentration: 3030 nM
Estimate against measurement, compound 4: 23-fold (1.36 log units) above, outside the stated range (below it).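

In this assay, hydrogen in place of fluoro on an aromatic carbon gives an at least 16-fold lower number from compound 2 to compound 4 (1.21 log units; beyond the scatter), which brings activity into the measurable range on this core. The same change from compound 1 to compound 3 cannot be sized, and neither can any other step among the limits, because an open limit sits at one or both ends: the limit of > 50000 nM in this assay, at which 3 of the 4 values shown sit. Compound 3 gives > 50000 nM, which is a limit of the assay, so the large step seen on the core of compound 2 does not show that the change works on every core in this series.

The compounds shown leave open whether compound 4 owes its measurable activity to the loss of fluoro alone or whether the rest of its structure is also needed. They also leave open what another group on that same aromatic carbon, such as chloro, a nitrile or an amine, would do to the read-out.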